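Imidazolium oxime series: lipophilicity notes toward compound 3

A few compounds are considered here, and "the series" means these few. Any claim that something is new, unique, unknown or untested is made for them only; others in the source may bear on it.

Measured so far:
- In a physicochemical assay for lipophilicity (a lower number here means a more polar compound, a higher number a more lipophilic compound), compound 1 `C[n+]1ccn(CCOCCCl)c1/C=N/O` gives -2.32.
- In this assay compound 2 `C[n+]1ccn(COCCCBr)c1/C=N/O` gives -1.76.

Compound 2 stands highest of the two numbers in this assay; its nearest neighbour is compound 1, and the step of a number 0.56 log units higher from compound 1 to compound 2 (beyond the scatter) lies beyond the scatter. Within the data shown here, that step, which exchanges one chain for another on the saturated chain carbon bound to an aromatic nitrogen, is the only measured step and the only one that bears on the next change.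

Compound 3 `CN(C)CCn1cc[n+](C)c1/C=N/O` is not yet measured. It differs from compound 2 by (dimethylamino)methyl in place of 3-bromopropoxy on a saturated chain carbon bound to an aromatic nitrogen. Among the measured compounds shown here, the one measured step at this place, a number 0.56 log units higher from compound 1 to compound 2 (beyond the scatter), was modest in size, so a step of comparable magnitude is expected here, and in the downward direction, giving compound 3 a value below that of compound 2 in this assay. The expected step is a number 0.94 log units lower from compound 2 to compound 3 (beyond the scatter) for compound 3. For the measured compounds named here, the estimate for compound 3 in this assay is -2.7, with a range from -3.4 to -2; the range is wide because only the single step of a number 0.56 log units higher from compound 1 to compound 2 (beyond the scatter) is available to anchor it.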

Compound 3, distribution coefficient: -3.06
Estimate against measurement, compound 3: 0.36 log units above, within the range that was stated.
By their numbers in this assay, from the lowest: compound 3; then compound 1; then compound 2.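

In this assay the change to (dimethylamino)methyl gives a number 1.30 log units lower from compound 2 to compound 3 (beyond the scatter) and dimethylamino in place of 2-chloroethoxy gives a number 0.74 log units lower from compound 1 to compound 3 (beyond the scatter) so compound 3 lies lowest of the three, and changes at this place are now seen to move the number down as well as up. Among these compounds, the step from the 3-bromopropoxy chain is large, whereas the only earlier step, between the two halogen-bearing ether chains, was modest, so this place allows a wider spread than compound 1 and compound 2 alone showed. The leaving and entering groups have the same printed counts of hydrogen-bond donors and acceptors and no net charge, so those counts do not separate compound 2 from compound 3, and nothing measured here accounts for the step.

The compounds shown leave open whether the lower number follows the dimethylamino group specifically or any amine on this chain, a question that a primary amine or a morpholine at the same place would address. They also leave open how the number responds to chain length, which a longer chain ending in dimethylamino would test.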